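The source may hold more compounds than are shown below. What is called first, only, known or untested is meant among the compounds shown, and "the series" means these compounds.

Measured compounds in the series:
compound 1, `O=C1O[C@H]([C@@H](O)Cn2cc(-c3ccc(Br)cc3)nn2)C(OCc2ccccc2)=C1OCc1ccccc1`, 750 nM
compound 2, `CCCCCCCCCCc1cn(C[C@H](O)[C@H]2OC(=O)C(OCc3ccccc3)=C2OCc2ccccc2)nn1`, 6750 nM

Both were run in a functional assay on A549 cells (Homo sapiens) for antiproliferative activity, read by MTT assay, with a stated time of 72 h; a higher number here means a weaker inhibitor, a lower number a stronger inhibitor. Among the measured compounds shown here, compound 1 stands lowest of the two numbers; the nearest is compound 2, which shows a 9.0-fold higher number from compound 1 to compound 2 (0.95 log units; beyond the scatter), the only measured step in the set, and it runs in the direction of a weaker inhibitor when the aromatic group is exchanged for a chain.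

Compound 3, `O=C1O[C@H]([C@@H](O)Cn2cc(CCCCl)nn2)C(OCc2ccccc2)=C1OCc1ccccc1`, has not yet been measured. It differs from compound 1 by 3-chloropropyl in place of 4-bromophenyl on an aromatic carbon.

The step from compound 1 to compound 2 is the one that bears on this change: there too a chain replaces the 4-bromophenyl on the same aromatic carbon, and the number rose well beyond the scatter. The chain entering in compound 3 is shorter than decyl and carries a chlorine, so the same direction is expected but a smaller size is plausible. For compound 3 the expectation in this assay is a 3.3-fold higher number from compound 1 to compound 3 (0.52 log units; beyond the scatter), a weaker inhibitor than compound 1. Compound 3 is estimated at 2500 nM, with a range from 900 nM to 7000 nM.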

Compound 3, half-maximal inhibitory concentration: 29000 nM
Beside the measured number, compound 3's estimate is 12-fold (1.06 log units) below it; the measured number lies above the stated range.
By their numbers in this assay, from the lowest: compound 1; then compound 2; then compound 3.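

At this aromatic carbon of the five-membered aromatic ring with 3 nitrogen, one chain does not predict another: in this assay the change to 3-chloropropyl gives a 39-fold higher number from compound 1 to compound 3 (1.59 log units; beyond the scatter) and so goes further than a 9.0-fold higher number from compound 1 to compound 2 (0.95 log units; beyond the scatter) on the same carbon. The shorter, chlorine-bearing chain also falls behind decyl, with a 4.3-fold higher number from compound 2 to compound 3 (0.63 log units; beyond the scatter) for chloro in place of heptyl on a saturated chain carbon, three bonds along the chain from an aromatic carbon, so among these three compounds a shorter chain wins back none of the loss seen with compound 2. No measurement at hand bears on what lies behind these steps.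

The compounds shown do not separate the shortening of the chain from the presence of its chlorine, and a plain propyl or a 3-hydroxypropyl chain on the same carbon would bear on that. They also leave open whether the benzene ring of 4-bromophenyl or its bromine carries the advantage of compound 1, a question that an unsubstituted phenyl or a 4-chlorophenyl group would address.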